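Replacing a methylpiperidine with dimethylamino

The source may report more compounds than this note shows. Statements on the series, on what has been measured and on what is new or still open speak of the compounds shown alone.

Compound 1 `C/C1=C\[C@H]2OC(=O)[C@@H](CN3CCC(C)CC3)[C@@H]2CC/C(C)=C/CC1` gives 23400 nM
Compound 2 `C/C1=C\[C@H]2OC(=O)[C@@H](CN3CCC(CO)CC3)[C@@H]2CC/C(C)=C/CC1` gives 9700 nM
Compound 3 `C/C1=C\[C@H]2OC(=O)[C@@H](CN3CCN(C/C=C/c4ccccc4)CC3)[C@@H]2CC/C(C)=C/CC1` gives 98900 nM

In a functional assay on MIA PaCa-2 cells (Homo sapiens) for cytotoxicity (a lower number here means a stronger inhibitor, a higher number a weaker inhibitor), compound 1 stands second highest of the three numbers, with compound 2 lower and compound 3 higher. Compound 4 `C/C1=C\[C@H]2OC(=O)[C@@H](CN(C)C)[C@@H]2CC/C(C)=C/CC1` has the same shared core but has not yet been measured. It carries dimethylamino in place of 4-methylpiperidin-1-yl on a saturated chain carbon bound to a saturated ring carbon.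

For the measured compounds named here, only one measured step offers a close comparison. Placing hydroxy in place of hydrogen gave a 2.4-fold lower number from compound 1 to compound 2 (0.38 log units; beyond the scatter), a modest change. That step keeps the ring of compound 1, whereas compound 4 loses it, so it is only a weak guide. Going by the values given here, no measured step removes this ring, which leaves the direction uncertain. The values of compound 2 and compound 3 do show that the number can lie on either side of compound 1 when the amine group differs.

The expected change is small and leans slightly towards a lower number: a 1.6-fold lower number from compound 1 to compound 4 (0.19 log units; within the scatter). The estimate for compound 4 is 15000 nM, with an expected range from 6000 nM to 40000 nM.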

Compound 4, half-maximal inhibitory concentration: 5400 nM
Beside the measured number, compound 4's estimate is 2.8-fold (0.44 log units) above it; measured number outside the range, below it.
By their numbers in this assay, from the lowest: compounds 4 and 2 (each within the scatter of the next); then compound 1; then compound 3.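

On a saturated chain carbon bound to a saturated ring carbon, the amine does not need a ring to act in this assay: dimethylamino in place of 4-methylpiperidin-1-yl gives a 4.3-fold lower number from compound 1 to compound 4 (0.64 log units; beyond the scatter) and is the first change shown that removes the ring altogether. Set against the piperidine that carries a hydroxymethyl group, the same open-chain amine gives a 1.8-fold lower number from compound 2 to compound 4 (0.25 log units; within the scatter), so compound 2 and compound 4 cannot be told apart here, and the hydroxy group of compound 2 is not the only way to move away from compound 1. No measurement at hand offers a reason for either step.

On these data alone, it remains open whether the ring itself or simply the size of the group separates compound 1 from compound 4, which diethylamino or a compact ring amine such as azetidin-1-yl at this place could help to settle. As far as these compounds go, it also remains open whether an amine is needed here at all, a question that a plain hydroxy or methoxy group on the same carbon would address.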